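Swapping carbamoyl for cyano on compound 3

The source may hold more compounds than are shown below. What is called first, only, known or untested is meant among the compounds shown, and "the series" means these compounds.

- compound 1 `COC(=O)C1=C(C)N=C(C)/C(=C(/O)OC)C1c1cccc(OCc2c(C)no[n+]2[O-])c1`: 400 nM
- compound 2 `COC(=O)C1=C(C)N=C(C)/C(=C(/O)OC)C1c1cccc(OCc2nonc2C(N)=O)c1`: 3500 nM
- compound 3 `COC(=O)C1=C(C)N=C(C)/C(=C(/O)OC)C1c1cccc(OCc2no[n+]([O-])c2C(N)=O)c1`: 710 nM
- compound 4 `COC(=O)C1=C(C)N=C(C)/C(=C(/O)OC)C1c1cccc(OCc2no[n+]([O-])c2C#N)c1`: not yet measured

All values come from a functional assay (aorta) with Rattus norvegicus as the target, in the presence of a further agent that is not named here (a lower number here means that less compound is needed, a higher number that more compound is needed for the effect), and the compounds share one core. Compound 3 lies within the scatter of compound 1 and well under compound 2 (a 4.9-fold lower number from compound 2 to compound 3 (0.69 log units; beyond the scatter)). The next change puts cyano in place of carbamoyl on an aromatic carbon. Among the compounds with values here, no measured pair makes this exact swap, so the evidence is indirect. Three steps alter the group carrying this position. One stays within the scatter (a 1.8-fold higher number from compound 1 to compound 3 (0.25 log units; within the scatter)), and the largest is still modest (an 8.8-fold higher number from compound 1 to compound 2 (0.94 log units; beyond the scatter)). A step of modest size at most is therefore expected in this assay, with no firm direction and only a slight lean towards a lower number. The estimated step is small (a 1.8-fold lower number from compound 3 to compound 4 (0.25 log units; within the scatter)). Compound 4 is expected at 400 nM (estimated range 100 nM to 1400 nM).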

Compound 4, half-maximal effective concentration: 3.3 nM
The estimate for compound 4 lay 120-fold (2.08 log units) above the measured number, and the stated range ends above it.
By their numbers in this assay, from the lowest: compound 4; then compounds 1 and 3 (each within the scatter of the next); then compound 2.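

In this assay, within the data shown here, this position on the ring proves far more sensitive than the earlier compounds suggested: cyano in place of carbamoyl gives a 220-fold lower number from compound 3 to compound 4 (2.33 log units; beyond the scatter), a larger step than any among the earlier compounds. The group carrying cyano also stands well clear of the other two groups on the chain carbon, with a 120-fold lower number from compound 1 to compound 4 (2.08 log units; beyond the scatter) and a 1100-fold lower number from compound 2 to compound 4 (3.03 log units; beyond the scatter). Nothing measured here explains the size of this change.

The compounds shown leave open whether cyano would give a similar step on the ring of compound 2, or whether the step depends on the ring of compound 3. They also leave open whether other groups at this position, such as a carboxylic acid, a methyl ester or an amine, would behave more like cyano or like carbamoyl.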